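The compounds below may be only part of what the source reports. "The series", "measured", "known", "first", "only" and "open" are said of these compounds alone.

Measured in a functional assay on MCF7 cells (Homo sapiens) for antiproliferative activity, read by MTT assay, with stated times of 24 h and 72 h (a higher number here means a weaker inhibitor, a lower number a stronger inhibitor), so far:
Compound 1 `COc1cccc([C@@H]2[C@H](Oc3ccccc3)C(=O)N2c2cc(OC)c(OC)c(OC)c2)c1` gives 171000 nM
Compound 2 `COc1ccc([C@@H]2[C@H](Oc3ccccc3)C(=O)N2c2cc(OC)c(OC)c(OC)c2)cc1OC` gives 26000 nM
Compound 3 `COc1cc(N2C(=O)[C@@H](Oc3ccccc3)[C@H]2c2ccc(Br)cc2)cc(OC)c1OC` gives 48000 nM

Compound 3 belongs to the lower two of these three numbers. Its gap to the other member of that pair is small, with a 1.8-fold higher number from compound 2 to compound 3 (0.27 log units; within the scatter) on record, while a 3.6-fold lower number from compound 1 to compound 3 (0.55 log units; beyond the scatter) separates it from the remaining compound.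

The compound still to be measured is compound 4 `COc1cc(N2C(=O)[C@@H](Oc3ccccc3)[C@H]2c2ccc(N(C)C)cc2)cc(OC)c1OC` and its difference from compound 3 is this: dimethylamino in place of bromo on an aromatic carbon with dimethylamino in place of bromo on an aromatic carbon, para to a large group.

For the measured compounds named here, no measured compound carries dimethylamino, so the evidence is indirect. The closest guide is the set of changes made to this same aromatic group. These are the two steps above, one within the scatter and one modest, together with a 6.6-fold lower number from compound 1 to compound 2 (0.82 log units; beyond the scatter) for an added methoxy. None of these steps is large, and together they give no firm direction for the new change.

A small step is therefore expected in this assay and the estimate means a 1.4-fold lower number from compound 3 to compound 4 (0.14 log units; within the scatter) as an expected shift that stays close to the scatter. In this assay compound 4 is estimated at 35000 nM with an expected range of 11000 nM to 120000 nM around it.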

Compound 4, half-maximal inhibitory concentration: 31000 nM
Estimate against measurement, compound 4: 1.1-fold (0.05 log units) above, within the range that was stated.
By their numbers in this assay, from the lowest: compounds 2, 4 and 3 (each within the scatter of the next); then compound 1.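

In this assay, the first group other than a halogen or methoxy at this place, on an aromatic carbon para to a large group, leaves the number within the scatter of the bromo compound (a 1.5-fold lower number from compound 3 to compound 4 (0.19 log units; within the scatter)), even though dimethylamino brings a nitrogen and a hydrogen-bond acceptor that bromo lacks. Compound 4 also stays within the scatter of the 3,4-dimethoxyphenyl compound (a 1.2-fold higher number from compound 2 to compound 4 (0.08 log units; within the scatter)) and remains apart from the 3-methoxyphenyl compound (a 5.5-fold lower number from compound 1 to compound 4 (0.74 log units; beyond the scatter)), so compound 2, compound 3 and compound 4, with their different aryl groups, give numbers within the scatter of one another, and only compound 1 stands apart. No measurement in hand speaks to why these groups give such close numbers.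

The compounds shown leave open whether this tolerance extends to a primary amine, a carboxylic acid or a longer chain such as an ethoxy group at the same place. They also leave open whether dimethylamino would give a similar number if moved to another carbon of the same aromatic ring, since every compound here with a single group on this ring other than compound 1 carries it at the one place.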